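A few compounds are considered here, and "the series" means these few. Any claim that something is new, unique, unknown or untested is made for them only; others in the source may bear on it.

Compound 2 `CCn1cc(C(=O)O)c(=O)c2cc(F)c(N3CCN(CN4C(=O)/C(=N\NC(=S)NOC)c5cc(F)ccc54)CC3)cc21` is examined in an ADME assay on MT4 cells (Homo sapiens) for cytotoxicity, read by spectrophotometry, with a stated time of 5 days; a higher number here means that more compound is tolerated, a lower number that less compound is tolerated. Compound 2 gives 144000 nM, which lies within the scatter of compound 1 `CONC(=S)N/N=C1\C(=O)N(CN2CCN(c3c(F)cc4c(=O)c(C(=O)O)cn(C5CC5)c4c3OC)CC2C)c2ccc(Cl)cc21` at 164000 nM and of compound 3 `CCn1cc(C(=O)O)c(=O)c2cc(F)c(N3CCN(CN4C(=O)/C(=N\NC(=S)NO)c5cc(F)ccc54)CC3)cc21` at 208000 nM. Within the data shown here, the only step measured between close neighbours, a 1.4-fold higher number from compound 2 to compound 3 (0.16 log units; within the scatter), concerns a change on an oxygen and not a halogen. Compound 4 `CCn1cc(C(=O)O)c(=O)c2cc(F)c(N3CCN(CN4C(=O)/C(=N\NC(=S)NOC)c5cc(Cl)ccc54)CC3)cc21` differs from compound 2 by chloro in place of fluoro on an aromatic carbon. Among the measured compounds shown here, no measured step covers a chloro in place of fluoro on this carbon; compound 1 carries a chloro but differs from compound 2 in many other places, so its number shows only that such a compound can sit in the same range. Compound 4 is therefore expected to show no step beyond the scatter, a 1.0-fold higher number from compound 2 to compound 4 (0.02 log units; within the scatter), with an estimated value of 150000 nM ranging from 80000 nM to 280000 nM.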

Compound 4, half-maximal cytotoxic concentration: 193000 nM
Compound 4: middle estimate off by 1.3-fold (0.11 log units), on the low side; low and high end bracket the measured number.
By their numbers in this assay, from the lowest: compounds 2, 1, 4 and 3 (each within the scatter of the next).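

In this assay, chloro in place of fluoro on this aromatic carbon gives a 1.3-fold higher number from compound 2 to compound 4 (0.13 log units; within the scatter) as a direct reading of this change between close neighbours. At this position, with the rest of the structure held constant, the number does not separate the two halogens. Nothing at hand bears on the reason for this result. From the compounds shown here alone, whether bromo, an amine or a methyl group on the same carbon would also stay within the scatter remains open. So does whether the same exchange would read alike on the core of compound 1.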